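From fluoro to (trifluoromethyl)sulfanyl on compound 2

This account rests on a few compounds, and the source may have more. Where it says the series, first, only, none or still open, it means among the compounds named here.

Among the measured compounds shown here, in a functional assay on Jurkat cells (Homo sapiens) for inhibition, read by MTT assay, with a stated time of 72 h (on this read-out higher numbers stand for weaker inhibition and lower numbers for stronger inhibition), compound 2 `C=C(Br)C(=O)Nc1cccc(/C=C/C(=O)Nc2ccc(F)cc2)c1` gives 6200 nM, the highest of the three numbers measured so far. Compound 1 `C=C(Br)C(=O)Nc1cccc(/C=C/C(=O)Nc2cccc3ccccc23)c1` gives 680 nM, and compound 3 `C=C(Br)C(=O)Nc1cccc(/C=C/C(=O)NCc2ccc(C)cc2)c1` gives 740 nM. Compound 4 `C=C(Br)C(=O)Nc1cccc(/C=C/C(=O)Nc2ccc(SC(F)(F)F)cc2)c1` differs from compound 2 in one place, described by (trifluoromethyl)sulfanyl in place of fluoro on an aromatic carbon, para to a large group. For the measured compounds named here, no measured compound carries this change. The nearest evidence is an 8.4-fold lower number from compound 2 to compound 3 (0.92 log units; beyond the scatter), a modest step. It replaces the whole 4-fluorophenyl on an amide-type nitrogen, so it bears on compound 4 only loosely. It does show that the number for compound 2 can fall when that group is altered, and compound 1, at 680 nM, also sits lower. A smaller step in the same direction is therefore expected, an estimated 3.4-fold lower number from compound 2 to compound 4 (0.54 log units; beyond the scatter). Compound 4 is expected to give about 1800 nM, with an estimated range from 600 nM to 5500 nM in this assay.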

Compound 4, half-maximal inhibitory concentration: 30100 nM
For compound 4 the middle estimate is 17-fold (1.22 log units) below the measured one; measured number outside the range, above it.
By their numbers in this assay, from the lowest: compounds 1 and 3 (each within the scatter of the next); then compound 2; then compound 4.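

In this assay, this single change on the aromatic ring weakens inhibition: a 4.9-fold higher number from compound 2 to compound 4 (0.69 log units; beyond the scatter). Among the compounds shown here, the only earlier step from compound 2, an 8.4-fold lower number from compound 2 to compound 3 (0.92 log units; beyond the scatter), replaced the whole 4-fluorophenyl and went the other way, so the opposite direction is new. It also shows that changing only the group on this aromatic carbon, para to a large group, can move the number beyond the scatter, and no measurement shown here accounts for the rise.

Going by these compounds, it remains open whether the higher number goes with the sulfur link or with the trifluoromethyl end of the new group. A plain trifluoromethyl, a methoxy group or an amine at this same place would help to separate these, and would show how far the number follows the choice of group here.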